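Two potent kinase inhibitors and a trimmed analogue

The source may hold more compounds than are shown below. What is called first, only, known or untested is meant among the compounds shown, and "the series" means these compounds.

Compound 1, with the structure `COc1cccc(CNC(=O)c2cn(CCN(C)C)c3cc(-c4cn[nH]c4)ccc23)c1`, was tested in an assay on isolated protein for inhibition of Rho-associated protein kinase 2 (Homo sapiens); on this read-out higher numbers stand for weaker inhibition and lower numbers for stronger inhibition. In this assay compound 1 gives < 1 nM, which is a limit of the assay rather than a number. Among the measured compounds shown here, compound 2, `COc1cccc(CNC(=O)c2cn(C)c3nc(-c4cn[nH]c4)ccc23)c1`, differs from compound 1 in more than one place, so no single step between them is followed here. In this assay compound 2 gives < 1 nM, again a limit. What the numbers show for compound 1 is only this: it sits at the limit of < 1 nM in this assay, at which 2 of the 2 values shown sit. Compound 3, `COc1cccc(CNC(=O)c2cn(C)c3cc(-c4cn[nH]c4)ccc23)c1`, has not yet been measured in this assay. It differs from compound 1 by hydrogen in place of (dimethylamino)methyl on a saturated chain carbon bound to an aromatic nitrogen. With both values shown resting at the same limit, the step expected from this change is a number no lower from compound 1 to compound 3 (the limit leaves the size open), meaning none beyond the scatter, and the inhibition is expected to stay strong. Compound 3 is estimated at 1 nM, within 0.3 nM to 5 nM.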

Compound 3, half-maximal inhibitory concentration: < 1 nM
Compound 3 ended at the assay's limit; the forecaster's own chance of this, stated with the estimate: 55%; the middle value sits exactly at the limit.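

Compound 1 and compound 3 each give only a limit rather than a number, so the step between them cannot be read: the limit of < 1 nM in this assay, at which 3 of the 3 values shown sit. The compounds shown leave open how strongly each truly inhibits, and whether changing 2-(dimethylamino)ethyl to methyl alters the inhibition at all.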